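Chloro added to compound 2: expected effect on permeability

The source may hold more compounds than are shown below. What is called first, only, known or untested is meant among the compounds shown, and "the series" means these compounds.

Measured so far:
- compound 1 `CCCCc1[nH]c(=O)c(S(=O)(=O)c2ccc(-c3ccncc3C)cc2)c(O)c1-c1c(OC)cccc1OC`: 355 nm/s
- compound 2 `CCCCc1[nH]c(=O)c(S(=O)(=O)c2ccc(-n3ccccc3=O)cc2)c(O)c1-c1c(OC)cccc1OC`: 177 nm/s

Compound 1 and compound 2 share a core and differ in one ring at the end of the sulfonyl-bearing aryl group. In an ADME assay for permeability, using PAMPA, at pH 5.5 (on this read-out lower numbers stand for lower permeability and higher numbers for higher permeability), compound 1 gives 355 nm/s, and in this assay compound 2 gives 177 nm/s. Going by the values given here, the step of a 2.0-fold lower number from compound 1 to compound 2 (0.30 log units; within the scatter) is the only measured step, and it lies within the scatter. Compound 2 therefore holds the lower of the two numbers, but by a margin that repeated measurement could erase.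

Compound 3 `CCCCc1[nH]c(=O)c(S(=O)(=O)c2ccc(-n3cc(Cl)ccc3=O)cc2)c(O)c1-c1c(OC)cccc1OC` is not yet measured. It differs from compound 2 by chloro in place of hydrogen on an aromatic carbon. Among the compounds with values here, no measured step involves this change: the one known step, from compound 1 to compound 2, swaps a whole ring, which bears only loosely on adding a single chloro. With nothing closer to lean on, the expected step of a 1.4-fold higher number from compound 2 to compound 3 (0.15 log units; within the scatter) is small. In this assay compound 3 is estimated at 250 nm/s, with a range from 110 nm/s to 560 nm/s.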

Compound 3, apparent permeability: 285 nm/s
Beside the measured number, compound 3's estimate is 1.1-fold (0.06 log units) below it; low and high end bracket the measured number.
By their numbers in this assay, from the lowest: compounds 2, 3 and 1 (each within the scatter of the next).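

In this assay, going by these compounds alone, the change of chloro in place of hydrogen, on the aromatic carbon two atoms from the ring nitrogen, reads as a 1.6-fold higher number from compound 2 to compound 3 (0.21 log units; within the scatter) and is the first measured step at this position, so this single added chlorine does not separate compound 3 from compound 2 beyond what repeated measurement would give. The ring swap, with chloro now on the ring, also stays small at a 1.2-fold lower number from compound 1 to compound 3 (0.10 log units; within the scatter) and so leaves compound 3 and compound 1 just as inseparable on this read-out as the unsubstituted pair were. The compounds shown come with no further measurement that could explain these small steps, so any reason for them stays unknown.

From the compounds shown here alone, whether a methyl, a methoxy, an amine or a carboxylic acid on this same aromatic carbon would also stay within the scatter of compound 2 remains open. Also open, going by these compounds, is whether chloro on another carbon of this ring, or a second chloro, would read the same way in this assay and whether any such group would give a step beyond the scatter.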